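The source may hold more compounds than are shown below. What is called first, only, known or untested is meant among the compounds shown, and "the series" means these compounds.

Measured compounds:
compound 1, `COc1ccc(Cn2c(-c3ccccc3)c(-c3ccccc3)c3c(=N)n(CC4CCCO4)cnc32)cc1`, > 1000 10^-6 cm/s;
compound 2, `COc1ccc(-c2c(-c3ccc(OC)cc3)n(Cc3ccccc3)c3ncn(CCO)c(=N)c23)cc1`, > 1000 10^-6 cm/s;
compound 3, `N=c1c2c(-c3ccccc3)c(-c3ccccc3)n(CC3CC3)c2ncn1CC1CCOCC1`, > 1000 10^-6 cm/s.

In an ADME assay for permeability, using PAMPA, with a stated time of 30 min, at pH 7.4 (on this read-out higher numbers stand for higher permeability and lower numbers for lower permeability), compound 2 gives > 1000 10^-6 cm/s, and this figure is a limit of the assay rather than a measured number. Compound 1 likewise gives only the limit > 1000 10^-6 cm/s. Compound 3 also reaches the limit > 1000 10^-6 cm/s. Thus every value so far sits at the limit of > 1000 10^-6 cm/s in this assay, at which 3 of the 3 values shown sit, and nothing separates compound 2 from the other two on the numbers shown.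

The compound not yet measured is compound 4, `COc1ccc(-c2c(-c3ccc(OC)cc3)n(Cc3ccccc3)c3ncn([C@H]4CC[C@H](O)CC4)c(=N)c23)cc1`. It differs from compound 2 by 4-hydroxycyclohexyl in place of 2-hydroxyethyl on an aromatic nitrogen. No step between measured compounds is available, so the size of this change in this assay cannot be read from the shown pairs. Given that compound 2 sits at > 1000 10^-6 cm/s, compound 4 is expected to remain in the same region, and the step of a number no higher from compound 2 to compound 4 (the limit leaves the size open) is expected to be none beyond the scatter. Compound 4 is estimated at 1000 10^-6 cm/s, between 500 10^-6 cm/s and 2000 10^-6 cm/s.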

Compound 4, apparent permeability: 196 10^-6 cm/s
Compound 4: the middle estimate sits 5.1-fold (0.71 log units) above what was measured, and the stated range ends above it.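

In this assay, 4-hydroxycyclohexyl in place of 2-hydroxyethyl on the aromatic nitrogen comes with an at least 5.1-fold lower number from compound 2 to compound 4 (0.70 log units; beyond the scatter). The two groups have the same count of hydrogen-bond donors and acceptors, so the change lies in the carbon count and the six-membered carbon ring, and the read-out at this position is shown not to stay at the limit whatever group sits there. Compound 4 is the only compound here with a measured number rather than a limit: the limit of > 1000 10^-6 cm/s in this assay, at which 3 of the 4 values shown sit.

From the compounds shown here alone, the full size of the step stays open, since the value for compound 2 is only a limit. Nor can the compounds shown separate the ring from the added carbons, and they leave open what an open-chain 4-hydroxybutyl, a plain cyclohexyl without the hydroxyl, or an amine at this nitrogen would give.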